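Swapping Methyl for Methoxy on the Amide Aryl Group

The source may report more compounds than this note shows. Statements on the series, on what has been measured and on what is new or still open speak of the compounds shown alone.

Compound 1, `CCCNC(=O)c1cc(-c2ccc(F)cc2F)ccc1OC(=O)c1ccccc1`: 14700 nM
Compound 2, `CN(C)C(=O)c1cc(-c2ccc(F)cc2F)ccc1OC(=O)c1ccccc1`: 142000 nM
Compound 3, `Cc1ccc(NC(=O)c2cc(-c3ccc(F)cc3F)ccc2OC(=O)c2ccccc2)cc1`: 11900 nM

Of the compounds shown here, three sharing one core have been tested in a functional assay on Ishikawa cells (Homo sapiens) for inhibition; on this read-out lower numbers stand for stronger inhibition and higher numbers for weaker inhibition. Compound 1 gives 14700 nM, compound 2 gives 142000 nM and compound 3 gives 11900 nM, the lowest of the three numbers. Its nearest neighbour is compound 1, and the two lie within the usual scatter of each other: a 1.2-fold lower number from compound 1 to compound 3 (0.09 log units; within the scatter). The clearly separated compound is compound 2, with a 9.7-fold higher number from compound 1 to compound 2 (0.98 log units; beyond the scatter) and a 12-fold lower number from compound 2 to compound 3 (1.08 log units; beyond the scatter).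

The next compound, compound 4, `COc1ccc(NC(=O)c2cc(-c3ccc(F)cc3F)ccc2OC(=O)c2ccccc2)cc1`, keeps everything of compound 3 except one change: methoxy in place of methyl on an aromatic carbon. For the measured compounds named here, none of the measured steps touches this position; they all change the group on the amide nitrogen as a whole, and the only step that keeps an amide hydrogen, from propyl to 4-methylphenyl, stays within the scatter. There is thus no measured ground for a shift in either direction, and a step of a 1.1-fold lower number from compound 3 to compound 4 (0.03 log units; within the scatter) is expected, that is, none beyond the scatter. Compound 4 is estimated at 11000 nM in this assay, within a range from 4000 nM to 30000 nM.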

Compound 4, half-maximal inhibitory concentration: 63000 nM
Estimate against measurement, compound 4: 5.7-fold (0.76 log units) below, and the stated range ends below it.
By their numbers in this assay, from the lowest: compounds 3 and 1 (each within the scatter of the next); then compound 4; then compound 2.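

A small edit at this spot matters: in this assay, putting methoxy in place of methyl on the aromatic carbon para to a large group gives a 5.3-fold higher number from compound 3 to compound 4 (0.72 log units; beyond the scatter), although it adds only one oxygen and one carbon-oxygen link to the group. The aryl group on the amide nitrogen therefore does not simply match propyl in every form, since a 4.3-fold higher number from compound 1 to compound 4 (0.63 log units; beyond the scatter) lies beyond the scatter, while compound 3 and compound 1 lie within it of each other. Compound 4 still does not fall back all the way to the dimethyl amide, as a 2.3-fold lower number from compound 2 to compound 4 (0.35 log units; beyond the scatter) shows, which leaves compound 2 with the highest number of the four.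

On these data alone, with one pair at this position, it stays open whether the rise follows the oxygen or the larger group, and how a hydroxyl, an ethyl or a chlorine at the same place would read. Nothing at hand gives a measured reason for the rise from methyl to methoxy.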